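Furan-to-pyrimidine swap on the benzyl-imidazole series

The compounds below may be only part of what the source reports. "The series", "measured", "known", "first", "only" and "open" are said of these compounds alone.

Of the compounds shown here, two have been measured in an assay for inhibition of steroid 17-alpha-hydroxylase/17,20 lyase (Homo sapiens), using NADPH, tested at 2 uM; on this read-out higher numbers stand for a stronger effect at the one concentration tested and lower numbers for a weaker effect. Compound 1, `c1cn(Cc2ccc(-c3ccoc3)cc2)cn1`, gives 29% in this assay and stands lowest of the two numbers. Within the data shown here, compound 2, `CCC(c1cc(-c2ccc(F)c(F)c2)cs1)n1ccnc1`, a different framework, gives 68% in this assay, a number well beyond the scatter above compound 1; no single-change step links these two, so only the two values themselves can be read.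

Compound 3, `c1cn(Cc2ccc(-c3cncnc3)cc2)cn1`, is not yet measured. It differs from compound 1 by pyrimidin-5-yl in place of furan-3-yl on an aromatic carbon, on an aromatic carbon of a six-membered aromatic ring of carbon only, para to a group of 6 heavy atoms. Among the measured compounds shown here, no measured pair shows this change, so its size is open; a step about the size of the scatter, leaning upward, is expected, namely a number 11 percentage points higher from compound 1 to compound 3 (beyond the scatter). Compound 3 is therefore estimated at 40% in this assay, within 15% to 70%.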

Compound 3, a percentage reported as inhibition, at one concentration (the size of the read-out at that concentration, not a potency): 3%
Compound 3: the middle estimate sits 37 percentage points above what was measured; measured number below the stated range.
By their numbers in this assay, from the lowest: compound 3; then compound 1; then compound 2.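

In this assay, pyrimidin-5-yl in place of furan-3-yl on this aromatic carbon gives a number 26 percentage points lower from compound 1 to compound 3 (beyond the scatter), so the read-out at this position depends on which aromatic ring it carries. Compound 3 reads 3%, leaving the furan-3-yl of compound 1 as the better of the two groups at this place on the shared core. Nothing available here speaks to the reason for this step.

The change replaces a five-membered aromatic ring with 1 hetero atom by a six-membered aromatic ring with 2 hetero atoms, so this single pair cannot separate ring size from hetero atom content. Going by these compounds, how a non-ring group such as an amine or a carboxylic acid would read on this aromatic carbon remains open, as does whether the same swap would behave alike on the framework of compound 2.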